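This account rests on a few compounds, and the source may have more. Where it says the series, first, only, none or still open, it means among the compounds named here.

Series notes. The shared core is that of compound 1 `O=S(=O)(NC1=NCCN1C(=S)SN1CCn2c1nsc2=S)c1ccc(C(F)(F)F)cc1`; compound 2 `COc1ccc(OC)c(S(=O)(=O)NC2=NCCN2C(=S)SN2CCn3c2nsc3=S)c1` and compound 3 `O=S(=O)(NC1=NCCN1C(=S)SN1CCn2c1nsc2=S)c1ccc(OC(F)(F)F)cc1` vary only the group on the sulfonyl sulfur. In a functional assay on KYSE-510 cells (Homo sapiens) for antiproliferative activity, read by crystal violet staining, with a stated time of 96 h (on this read-out higher numbers stand for weaker inhibition of growth and lower numbers for stronger inhibition of growth), compound 1 gives >= 20000 nM, which is a limit of the assay and not a number. In this assay compound 2 gives >= 20000 nM, again a limit. In this assay compound 3 gives >= 20000 nM, also a limit. All three values sit at the limit of >= 20000 nM in this assay, at which 3 of the 3 values shown sit, so compound 3 stands at the same limit as compound 1 and compound 2 and cannot be placed relative to them. The step that the two limits leave unreadable from compound 1 to compound 2 and the step that the two limits leave unreadable from compound 1 to compound 3 are both unreadable, because two limits leave no size to be read (the limit of >= 20000 nM in this assay, at which 3 of the 3 values shown sit).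

The next compound, compound 4 `CC(=O)Nc1ccc(S(=O)(=O)NC2=NCCN2C(=S)SN2CCn3c2nsc3=S)cc1`, differs from compound 3 by acetamido in place of trifluoromethoxy on an aromatic carbon. For the measured compounds named here, no measured step bears directly on this change, and the two steps seen in this assay have no readable size. Carried over from three limits, the expectation for compound 4 is a further limit rather than a number. The step that the limit leaves unreadable from compound 3 to compound 4 is therefore estimated at no readable size. Compound 4 is estimated at 25000 nM in this assay, with a range from 8000 nM to 80000 nM.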

Compound 4, concentration for 50% growth inhibition: >= 20000 nM
Compound 4 gave a limit, no number; the forecaster's own chance of this, stated with the estimate: 70%; the middle value is on the limit's open side.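

No step from compound 1, compound 2 or compound 3 to compound 4 can be read, because compound 4 also gives a limit and not a number in this assay: the limit of >= 20000 nM in this assay, at which 4 of the 4 values shown sit.

The compounds shown leave open whether any group on the sulfonyl sulfur of the shared core gives a value inside the readable range of this assay.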